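The source may report more compounds than this note shows. Statements on the series, on what has been measured and on what is new or still open speak of the compounds shown alone.

In an in vitro ADME assay on microsomes from liver (Homo sapiens) for pharmacokinetics (on this read-out higher numbers stand for fast clearance and lower numbers for slow clearance), three compounds sharing one core, and differing in the group on a carbonyl carbon, have been measured. Compound 1 (`Cc1cc(S(=O)(=O)N2C=CNC(=O)[C@H]2CC(=O)N[C@H]2CCNCC2(C)C)c(C)cc1Cl`) gives 21 mL.min-1.g-1, compound 3 (`Cc1cc(S(=O)(=O)N2C=CNC(=O)[C@H]2CC(=O)N2CCCC(N(C)C)CC2)c(C)cc1Cl`) gives 64 mL.min-1.g-1 and compound 2 (`Cc1cc(S(=O)(=O)N2C=CNC(=O)[C@H]2CC(=O)N2CCC[C@H](N3CCCC3)C2)c(C)cc1Cl`) gives 235 mL.min-1.g-1, which puts compound 3 in the middle. Compound 4 (`Cc1cc(S(=O)(=O)N2C=CNC(=O)[C@H]2CC(=O)N2CCCCC(N(C)C)CC2)c(C)cc1Cl`) has not yet been measured, and its change from compound 3 is this: a group of 11 heavy atoms (9 carbon, 2 nitrogen; one eight-membered non-aromatic ring with 1 hetero atom) in place of a group of 10 heavy atoms (8 carbon, 2 nitrogen; one seven-membered non-aromatic ring with 1 hetero atom), on a carbonyl carbon. Within the data shown here, no measured pair shows this exact swap of a seven-membered ring for an eight-membered one, so the guides are indirect. The closest is a 3.0-fold higher number from compound 1 to compound 3 (0.48 log units; beyond the scatter), where the group also gains one heavy atom. The step of a 3.7-fold lower number from compound 2 to compound 3 (0.56 log units; beyond the scatter) and the large step of an 11-fold higher number from compound 1 to compound 2 (1.05 log units; beyond the scatter) fit the same trend, with the number rising as the group grows in all three compounds. Three compounds are a thin basis, but a further modest rise in this assay is expected. The expected step is a 2.2-fold higher number from compound 3 to compound 4 (0.34 log units; beyond the scatter). For compound 4 the estimated value is 140 mL.min-1.g-1, with an expected range from 65 mL.min-1.g-1 to 300 mL.min-1.g-1.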

Compound 4, intrinsic clearance in microsomes: 60 mL.min-1.g-1
For compound 4 the middle estimate is 2.3-fold (0.37 log units) above the measured one, outside the stated range (below it).
By their numbers in this assay, from the lowest: compound 1; then compounds 4 and 3 (each within the scatter of the next); then compound 2.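

In this assay the group of 11 heavy atoms with the eight-membered ring, in place of the group of 10 heavy atoms with the seven-membered ring on the carbonyl carbon, gives a 1.1-fold lower number from compound 3 to compound 4 (0.03 log units; within the scatter) and so no readable change at this position. Heavy-atom count alone does not set the number here, since the two groups of 11 heavy atoms are separated by a 3.9-fold lower number from compound 2 to compound 4 (0.59 log units; beyond the scatter) and the step of a 2.9-fold higher number from compound 1 to compound 4 (0.46 log units; beyond the scatter) remains beyond the scatter. Nothing available explains these differences.

Open, going by these compounds, is how the number would respond to a hydroxyl group or a carboxylic acid in place of the amine on the ring. Also open, on these data alone, is whether a nine-membered ring would likewise stay within the scatter of the seven-membered and eight-membered rings.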